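Sulfonamide aryl variation in a CXCR4 binding series

The source may hold more compounds than are shown below. What is called first, only, known or untested is meant among the compounds shown, and "the series" means these compounds.

Measured compounds in an assay on MDA-MB-231 cells for binding affinity to C-X-C chemokine receptor type 4 (Homo sapiens), read by microscopy, with stated times of 10 min and 30 min; a higher number here means that more compound is needed for the effect, a lower number that less compound is needed:
- compound 1 `O=C(NCc1ccc(CNS(=O)(=O)c2ccc([N+](=O)[O-])cc2)cc1)c1ccc(CNc2ncccn2)cc1` gives 1000 nM
- compound 2 `O=C(NCc1ccc(CNS(=O)(=O)c2ccc3c(c2)CCO3)cc1)c1ccc(CNc2ncccn2)cc1` gives 1000 nM
- compound 3 `O=C(NCc1ccc(CNS(=O)(=O)c2cccnc2)cc1)c1ccc(CNc2ncccn2)cc1` gives > 1000 nM, which is a limit of this assay and not a number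

Within the data shown here, compound 1 sits level with compound 2 at the digits reported; the only other value in the set is the limit just named (the limit of > 1000 nM in this assay, at which 1 of the 3 values shown sits). Both measured steps change the aryl group on the sulfonyl sulfur: no change at the digits printed from compound 1 to compound 2 (within the scatter), and a number no lower from compound 1 to compound 3 (the limit leaves the size open). The second of these has a size that cannot be read.

Compound 4 `Cc1ccc(S(=O)(=O)NCc2ccc(CNC(=O)c3ccc(CNc4ncccn4)cc3)cc2)cc1` differs from compound 1 in one place: methyl in place of nitro on an aromatic carbon. It is the smallest change in this set, from 4-nitrophenyl to 4-methylphenyl. The step from compound 1 to compound 2 shows that a larger exchange at this position left the value unchanged, while the step from compound 1 to compound 3 leaves open a loss. Compound 4 is therefore expected to stay near compound 1, with the step of no change at the digits printed from compound 1 to compound 4 (within the scatter) expected to fall within the scatter. The estimate for compound 4 is 1000 nM, with a range from 300 nM to 3000 nM.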

Compound 4, effective concentration (reported as EC, without a stated level of effect): 100 nM
Compound 4: the middle estimate sits 10-fold (1.00 log units) above what was measured; measured number below the stated range.
By their numbers in this assay, from the lowest: compound 4; then compounds 1 and 2 (each within the scatter of the next).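

Among these compounds, exchanging nitro for methyl is the first change at this position to give a step beyond the scatter in this assay: a 10-fold lower number from compound 1 to compound 4 (1.00 log units; beyond the scatter). The aryl group on the sulfonyl sulfur therefore matters to the number, which the unchanged pair of compound 1 and compound 2 did not show, and 4-methylphenyl also stands apart in a 10-fold lower number from compound 2 to compound 4 (1.00 log units; beyond the scatter) and in an at least 10-fold lower number from compound 3 to compound 4 (1.00 log units; beyond the scatter). The value of compound 3 is a limit of the assay and not a number: the limit of > 1000 nM in this assay, at which 1 of the 4 values shown sits.

No measurement shown bears on why methyl gives the lower number. On these data alone, whether 4-aminophenyl or 4-ethylphenyl would match compound 4 stays open, as does whether the step from nitro to methyl would hold with other changes to the shared core.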